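Cyclopentyl in Place of Pyridin-2-yl on the Amide

The source may hold more compounds than are shown below. What is called first, only, known or untested is meant among the compounds shown, and "the series" means these compounds.

In an in vitro ADME assay on microsomes from liver (Homo sapiens) for pharmacokinetics, read by LC-MS, with a stated time of 10 min, tested at 1 uM (on this read-out lower numbers stand for slow clearance and higher numbers for fast clearance), compound 1 (`CC(C)c1ccc(NC(=O)[C@H]2CN(C)C[C@@H]2c2ccc(/C=C/C(=O)Nc3ccccc3N)cc2)cc1`) gives 10 mL/min/kg and compound 2 (`Cc1ccc(NC(=O)[C@H]2CN(C)C[C@@H]2c2ccc(/C=C/C(=O)Nc3ccccc3N)cc2)cn1`) gives 8 mL/min/kg there. Compound 3 (`CN1C[C@H](C(=O)Nc2ccccn2)[C@@H](c2ccc(/C=C/C(=O)Nc3ccccc3N)cc2)C1`) gives 8 mL/min/kg and so stands level with compound 2 and within the scatter of compound 1.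

Compound 4 (`CN1C[C@H](C(=O)NC2CCCC2)[C@@H](c2ccc(/C=C/C(=O)Nc3ccccc3N)cc2)C1`) differs from compound 3 in one place, with cyclopentyl in place of pyridin-2-yl on an amide-type nitrogen.

Three measured steps change the group on that same nitrogen. Going from 4-isopropylphenyl to pyridin-2-yl gave a 1.3-fold lower number from compound 1 to compound 3 (0.10 log units; within the scatter) and going from 4-isopropylphenyl to 6-methylpyridin-3-yl gave a 1.3-fold lower number from compound 1 to compound 2 (0.10 log units; within the scatter) while exchanging the two pyridinyl groups gave no change at the digits printed from compound 2 to compound 3 (within the scatter) in the same measurement. Among the compounds with values here, none of these steps puts a non-aromatic ring on that nitrogen, so the data hold no direct precedent for cyclopentyl. Since compound 3 stands at 8 mL/min/kg and all three steps stayed within the scatter, no step beyond the scatter is expected in this assay here. The expected step is a 1.3-fold higher number from compound 3 to compound 4 (0.10 log units; within the scatter) and no firm direction is claimed for it. Compound 4 is estimated at 10 mL/min/kg with an expected range from 5 mL/min/kg to 20 mL/min/kg for the measurement.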

Compound 4, clearance: 9 mL/min/kg
The estimate for compound 4 lay 1.1-fold (0.05 log units) above the measured number, and the stated range covers the measured number.
By their numbers in this assay, from the lowest: compounds 2, 3, 4 and 1 (each within the scatter of the next).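

In this assay, the first non-aromatic ring on the amide-type nitrogen gives a 1.1-fold higher number from compound 3 to compound 4 (0.05 log units; within the scatter), while the comparisons with the other two groups give a 1.1-fold higher number from compound 2 to compound 4 (0.05 log units; within the scatter) and a 1.1-fold lower number from compound 1 to compound 4 (0.05 log units; within the scatter). Cyclopentyl, a five-membered non-aromatic ring of carbon only, therefore stays within the scatter of pyridin-2-yl, 6-methylpyridin-3-yl and 4-isopropylphenyl, so among these four groups an aromatic ring on that nitrogen is not needed for a number at this level. No measurement available here accounts for this result.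

The compounds shown leave open whether a group carrying an amine or a carboxylic acid on that nitrogen, or an open butyl chain in place of the ring, would also stay within the scatter. Nor do they show whether a smaller carbon ring, such as cyclopropyl, would do the same.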